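Dimethylphenyl Replaces Methoxyphenyl in a Sulfonamide Series

The compounds below may be only part of what the source reports. "The series", "measured", "known", "first", "only" and "open" are said of these compounds alone.

Of the compounds shown here, three sharing one core have been tested in a functional assay on HT-29 cells (Homo sapiens) for antiproliferative activity, read by sulforhodamine B assay, with a stated time of 48 h; a higher number here means a weaker inhibitor, a lower number a stronger inhibitor. Compound 1 `CCc1ccccc1NS(=O)(=O)c1ccc(N2CCNC2=O)cc1` gives 240 nM, compound 2 `COc1ccccc1NS(=O)(=O)c1ccc(N2CCNC2=O)cc1` gives 550 nM, and compound 3 `COc1cccc(NS(=O)(=O)c2ccc(N3CCNC3=O)cc2)c1` gives 120 nM. Compound 3 thus holds the lowest number of the three: the step of a 2.0-fold lower number from compound 1 to compound 3 (0.30 log units; within the scatter) lies within the scatter, while the step of a 4.6-fold lower number from compound 2 to compound 3 (0.66 log units; beyond the scatter) does not.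

Compound 4 `Cc1cccc(NS(=O)(=O)c2ccc(N3CCNC3=O)cc2)c1C` has not yet been measured. It differs from compound 3 as follows: 2,3-dimethylphenyl in place of 3-methoxyphenyl on a sulfonamide nitrogen.

Among the measured compounds shown here, two measured steps bear on this change. The step of a 2.3-fold higher number from compound 1 to compound 2 (0.36 log units; beyond the scatter) shows that exchanging an alkyl group for a methoxy group on the aromatic carbon gave a modestly higher number, so the reverse direction, toward carbon-only substituents, points toward a lower number. The step of a 4.6-fold lower number from compound 2 to compound 3 (0.66 log units; beyond the scatter) shows that placing the substituent as in a 3-substituted phenyl rather than a 2-substituted phenyl gave a modestly lower number; compound 4 carries substituents of both kinds. These pulls partly offset, so compound 4 is expected to stay close to compound 3, with a step of a 1.1-fold higher number from compound 3 to compound 4 (0.03 log units; within the scatter) no larger than the scatter. Compound 4 is estimated at 130 nM, within 50 nM to 350 nM.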

Compound 4, half-maximal inhibitory concentration: 190 nM
The estimate for compound 4 lay 1.5-fold (0.16 log units) below the measured number; the measured number falls inside the stated range.
By their numbers in this assay, from the lowest: compounds 3, 4 and 1 (each within the scatter of the next); then compound 2.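

In this assay, the step of a 1.6-fold higher number from compound 3 to compound 4 (0.20 log units; within the scatter) stays within the scatter, showing that on this sulfonamide nitrogen 2,3-dimethylphenyl, which has no oxygen and no hydrogen-bond acceptor, can take the place of 3-methoxyphenyl without a change that can be read. The step of a 1.3-fold lower number from compound 1 to compound 4 (0.10 log units; within the scatter) is also within the scatter, whereas the step of a 2.9-fold lower number from compound 2 to compound 4 (0.46 log units; beyond the scatter) lies beyond it, so compound 2 with its 2-methoxyphenyl group remains apart from the other three compounds. No measurement offered here explains these numbers.

The compounds shown leave open how this position would respond to a phenyl group carrying an amine, a hydroxyl or a carboxylic acid. They also do not tell how a single methyl group or a chain longer than ethyl would compare.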